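Carbamate nitrogen substituent: cyclohexyl analogue of compound 2

The source may report more compounds than this note shows. Statements on the series, on what has been measured and on what is new or still open speak of the compounds shown alone.

Compound 1 `CCCCNC(=O)OC/C=C(\C)C1=CC(=O)C(C)(C)O1` and compound 2 `C/C(=C\COC(=O)NC(C)C)C1=CC(=O)C(C)(C)O1` share the same core and differ only in the group on the amide-type nitrogen of the carbamate. In a functional assay on L1210 cells (Mus musculus) for inhibition (on this read-out lower numbers stand for stronger inhibition and higher numbers for weaker inhibition), compound 1 gives 2.6 ug/mL, and compound 2 gives 4.9 ug/mL. Within the data shown here, the only measured step, a 1.9-fold higher number from compound 1 to compound 2 (0.28 log units; within the scatter), lies within the scatter, so the two numbers cannot be ordered. Among the measured compounds shown here, compound 2 thus carries the higher of the two numbers, with compound 1 as its only neighbour, and the gap between them is within the scatter.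

Compound 3 `C/C(=C\COC(=O)NC1CCCCC1)C1=CC(=O)C(C)(C)O1` is not yet measured. It differs from compound 2 by cyclohexyl in place of isopropyl on an amide-type nitrogen. For the measured compounds named here, the one measured step that bears on a change of the group on this nitrogen is the swap from butyl to isopropyl, which shifted this assay by a step within the scatter. Nothing measured distinguishes a ring from a chain at this position. The expected step is therefore a 1.4-fold lower number from compound 2 to compound 3 (0.15 log units; within the scatter), no size beyond the scatter in either direction. The estimate for compound 3 in this assay is 3.5 ug/mL, with a range from 1.5 ug/mL to 8 ug/mL.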

Compound 3, half-maximal inhibitory concentration: 3.7 ug/mL
Compound 3: the middle estimate sits 1.1-fold (0.02 log units) below what was measured, within the range that was stated.
By their numbers in this assay, from the lowest: compounds 1, 3 and 2 (each within the scatter of the next).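

In this assay, cyclohexyl in place of isopropyl on the amide-type nitrogen gives a 1.3-fold lower number from compound 2 to compound 3 (0.12 log units; within the scatter), and cyclohexyl in place of butyl gives a 1.4-fold higher number from compound 1 to compound 3 (0.15 log units; within the scatter), so neither step separates the ring from the two open chains. Until now, this position had been shown only with open chains; compound 3 adds a six-membered non-aromatic ring of carbon only and more heavy atoms than isopropyl, yet compounds 1, 2 and 3 still cannot be ordered, and the three groups give no pattern of size or shape on this read-out. No measurement on hand accounts for this flat picture.

Still open is whether a phenyl ring, a longer chain such as octyl, or a chain ending in an amine or a carboxylic acid on this nitrogen would give a step beyond the scatter, since all three groups shown are plain saturated carbon groups. Also open is what happens when the amide hydrogen gives way to a methyl group, as every compound shown keeps that hydrogen on the carbamate nitrogen.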